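The source may hold more compounds than are shown below. What is called first, only, known or untested is meant among the compounds shown, and "the series" means these compounds.

Of the compounds shown here, two have numbers so far in a functional assay on Caco-2 cells (Homo sapiens) for inhibition, read by MTT assay, with a stated time of 48 h, tested at 10 uM; on this read-out lower numbers stand for less inhibition of growth and higher numbers for more inhibition of growth at the one concentration tested. Compound 1 `Cc1cc(=O)c2c(O)cc(OCc3ccccc3)c([C@H]3CCN(C)C[C@H]3O)c2o1` gives 18%, and compound 2 `Cc1oc2c([C@H]3CCN(C)C[C@H]3O)c(O)cc(O)c2c(=O)c1C(O)c1ccccc1Br` gives 7%. Compound 2 therefore holds the lower of the two numbers, and its gap to compound 1 lies beyond the usual scatter of such measurements.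

The next compound to be read is compound 3 `Cc1oc2c([C@H]3CCN(C)C[C@H]3O)c(O)cc(O)c2c(=O)c1C(O)c1cc(F)cc(F)c1`, which differs from compound 2 in one place: 3,5-difluorophenyl in place of 2-bromophenyl on a saturated chain carbon bound to an aromatic carbon and an oxygen on a saturated carbon. In words, 3,5-difluorophenyl stands in place of 2-bromophenyl on a saturated chain carbon bound to an aromatic carbon and an oxygen on a saturated carbon.

Among the compounds with values here, no measured pair shows what an exchange of this kind does in this assay, so the data offer no direct precedent. The expectation rests on compound 2 and its 7%, and no change beyond the scatter is foreseen, though a rise towards the level of compound 1 cannot be excluded. The expected move is a number 3 percentage points higher from compound 2 to compound 3 (within the scatter), which is estimated to stay within the scatter. Compound 3 is expected at 10%, with an estimated range from 2% to 22%.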

Compound 3, percent growth inhibition at one concentration: 10%
Compound 3: middle estimate and measured number agree at the digits printed; the range from low to high includes it.
By their numbers in this assay, from the lowest: compounds 2, 3 and 1 (each within the scatter of the next, the first and the last beyond it).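

In this assay, the exchange of 2-bromophenyl for 3,5-difluorophenyl on the saturated chain carbon bound to an aromatic carbon and an oxygen on a saturated carbon gives a number 3 percentage points higher from compound 2 to compound 3 (within the scatter). This is the only pair shown that differs in one place, and it shows that this position can carry either of these two halogen-bearing phenyl groups, one with a single bromine and one with two fluorines, without a difference that this read-out can separate. Nothing at hand offers an explanation for this outcome.

Both groups are phenyl rings carrying halogens, so the compounds shown leave open whether a plain phenyl, a pyridyl ring, a methoxyphenyl group or a simple alkyl chain at this position would give a number that stands apart from those of compound 2 and compound 3 in this assay. They also leave open what happens when the hydroxy group of the (3,5-difluorophenyl)(hydroxy)methyl unit gives way to a ketone carbonyl or a methoxy group.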